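A Carbamate Variant of a Tracheal Relaxant Core

This account rests on a few compounds, and the source may have more. Where it says the series, first, only, none or still open, it means among the compounds named here.

Compound 1 `CC(=O)Oc1ccc2c(c1)C(n1ccccc1=O)=CC(C)(C)O2` carries an acetyl group on an oxygen on an aromatic ring of the shared core. In a functional assay (trachea) with Rattus norvegicus as the target (a lower number here means a less potent compound, a higher number a more potent compound, by a factor of ten per unit of this negative logarithm), compound 1 gives 4.97. Among the compounds with values here, the only other number so far belongs to compound 2 `CC1(C)C=C(n2ccccc2=O)c2cc(OCC(=O)c3ccc(F)cc3)ccc2O1`, which gives 4.77; the step between them, a number 0.20 log units lower from compound 1 to compound 2 (within the scatter), lies within the scatter, so neither compound can be called more potent than the other.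

Compound 3 `CC1(C)C=C(n2ccccc2=O)c2cc(OC(=O)Nc3ccccc3C(F)(F)F)ccc2O1` has not yet been measured. (2-(trifluoromethyl)phenyl)amino in place of methyl on a carbonyl carbon One measured step bears on this change: it also put a different group in place of acetyl on an oxygen on an aromatic ring, namely ((4-fluorophenyl)carbonyl)methyl, and it gave a number 0.20 log units lower from compound 1 to compound 2 (within the scatter), no movement beyond the scatter. Within the data shown here, with only that step to go on, and it showing no real change, compound 3 is expected to stay close to compound 1, with an estimated step of a number 0.07 log units lower from compound 1 to compound 3 (within the scatter). In this assay compound 3 is therefore estimated at 4.9, expected to fall between 4.3 and 5.5.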

Compound 3, logarithm of the reciprocal of the active concentration, log(1/C): 5.19
The estimate for compound 3 lay 0.29 log units below the measured number, within the range that was stated.
By their numbers in this assay, from the lowest: compounds 2, 1 and 3 (each within the scatter of the next, the first and the last beyond it).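

On the carbonyl carbon of the group attached to the ring oxygen, the small methyl of compound 1 can be replaced by the far larger (2-(trifluoromethyl)phenyl)amino, which adds an aromatic ring and a hydrogen-bond donor, and the step in this assay is a number 0.22 log units higher from compound 1 to compound 3 (within the scatter). This position therefore accepts a carbamate without a measurable change from compound 1, yet the group here is not irrelevant: in this assay, compound 2 gives 4.77 and compound 3 gives 5.19, and these two lie beyond the scatter of each other, though neither stands apart from compound 1. No measurement is available that would explain these numbers.

The compounds shown leave open which part of the new group matters, the amino nitrogen with its hydrogen, the aromatic ring, or the trifluoromethyl. A plain phenylamino or a methylamino group on the same carbonyl carbon would help to separate these parts and show whether the small difference between compound 2 and compound 3 can be widened.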